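Benzyl ring substitution in the cyanoacrylamide series

A few compounds are considered here, and "the series" means these few. Any claim that something is new, unique, unknown or untested is made for them only; others in the source may bear on it.

Compound 1 `N#C/C(=C\c1ccccc1OS(=O)(=O)c1ccccc1[N+](=O)[O-])C(=O)Nc1nnc(Cc2ccccc2)s1`: 71%
Compound 2 `N#C/C(=C\c1ccccc1OS(=O)(=O)c1ccccc1[N+](=O)[O-])C(=O)Nc1nnc(Cc2cccc(F)c2)s1`: 68%
Compound 3 `N#C/C(=C\c1ccccc1OS(=O)(=O)c1ccccc1[N+](=O)[O-])C(=O)Nc1nnc(Cc2ccc(Cl)cc2)s1`: 65%

In a functional assay on RS4-11 cells (Homo sapiens) for inhibition, read by CCK-8 assay, with a stated time of 48 h, tested at 20 uM (a lower number here means less inhibition of growth, a higher number more inhibition of growth at the concentration tested), compound 3 gives 65%, and it stands within the scatter of the other two measured compounds. The steps to it are a number 6 percentage points lower from compound 1 to compound 3 (within the scatter) and a number 3 percentage points lower from compound 2 to compound 3 (within the scatter).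

Next is compound 4 `Cc1ccc(Cc2nnc(NC(=O)/C(C#N)=C/c3ccccc3OS(=O)(=O)c3ccccc3[N+](=O)[O-])s2)cc1`, which carries methyl in place of chloro on an aromatic carbon, para to a large group, so that 4-chlorobenzyl becomes 4-methylbenzyl: methyl in place of chloro on an aromatic carbon.

Within the data shown here, no measured step makes this exact exchange. The nearest evidence is on the same ring. Chloro in place of hydrogen gave a number 6 percentage points lower from compound 1 to compound 3 (within the scatter), and fluoro in place of hydrogen gave a number 3 percentage points lower from compound 1 to compound 2 (within the scatter). Neither substitution moved the read-out beyond the scatter, so no step beyond the scatter is expected here, and no direction can be argued from these data. The expected step is a number 2 percentage points higher from compound 3 to compound 4 (within the scatter). The estimate for compound 4 is 67%, with an expected range of 57% to 77%.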

Compound 4, percent growth inhibition at one concentration: "not active" (no number reported)
Compound 4: no number reported; the estimate stays without a comparison.
By their numbers in this assay, from the lowest: compounds 3, 2 and 1 (each within the scatter of the next).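

Among these compounds, compound 4 is reported in this assay as not active, without a number, so no step from compound 3 or any other compound can be read. Nothing shown here bears on a cause for this result. The compounds shown leave open how far 4-methylbenzyl in place of 4-chlorobenzyl separates compound 4 from compound 3.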